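A few compounds are considered here, and "the series" means these few. Any claim that something is new, unique, unknown or untested is made for them only; others in the source may bear on it.

Three compounds have so far been characterised in an assay on HEK293 cells for activation of Kir3.1/Kir3.2 (Homo sapiens), read by thallium flux; on this read-out higher numbers stand for an effect only at larger amounts of compound and lower numbers for an effect already at smaller amounts. For the measured compounds named here, compound 1 `Cc1cc(NC(=O)Cn2nnc(-c3ccccc3)n2)n(C2CCC(F)(F)CC2)n1` gives 84 nM in this assay, and compound 2 `Cc1cc(NC(=O)Cn2nnc(-c3ccccc3)n2)n(Cc2ccccc2)n1` gives 495 nM; the only step between two measured compounds that differ in one place is a 5.9-fold higher number from compound 1 to compound 2 (0.77 log units; beyond the scatter), a change that sits on the aromatic nitrogen of the shared core. Compound 3 `Cc1cc(NC(=O)Cn2nnc(-c3cc(Cl)cc(Cl)c3)n2)n(C2CCCCC2)n1` gives 980 nM, the highest of the three numbers, sitting within the usual scatter of compound 2 but beyond it relative to compound 1.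

Compound 4 `Cc1cc(NC(=O)Cn2nnc(-c3cccc(C#N)c3)n2)n(C2CCCCC2)n1` is the next compound to be measured. Its difference from compound 3 is 3-cyanophenyl in place of 3,5-dichlorophenyl on an aromatic carbon. Going by the values given here, none of the measured steps touches this position: the one step recorded lies on the aromatic nitrogen, not on the aromatic carbon that bears the phenyl group, so it gives no direct guide to the size or direction of the change from compound 3 to compound 4. Among the compounds with values here, with no relevant precedent among the compounds already measured, no step beyond the scatter is expected in this assay; the estimated step is a 1.0-fold higher number from compound 3 to compound 4 (0.01 log units; within the scatter). Compound 4 is therefore expected to give about 1000 nM in this assay, within a range from 250 nM to 4000 nM.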

Compound 4, half-maximal effective concentration: 183 nM
For compound 4 the middle estimate is 5.5-fold (0.74 log units) above the measured one; the measured number lies below the stated range.
By their numbers in this assay, from the lowest: compound 1; then compound 4; then compounds 2 and 3 (each within the scatter of the next).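

For the compounds shown here, exchanging 3,5-dichlorophenyl for 3-cyanophenyl on the aromatic carbon of the five-membered ring gives a 5.4-fold lower number from compound 3 to compound 4 (0.73 log units; beyond the scatter) in this assay and shows for the first time that the group at this position can move the number beyond the scatter. Going by these compounds alone, the only earlier step, a 5.9-fold higher number from compound 1 to compound 2 (0.77 log units; beyond the scatter) on the aromatic nitrogen, said nothing about this position, so two separate places on the shared core now have a measured effect. The change takes away both chlorine atoms and brings in a nitrile with its one hydrogen-bond acceptor, but nothing given here accounts for the step.

The compounds shown do not separate the loss of the chlorine atoms from the arrival of the nitrile, a question that 3-chlorophenyl or unsubstituted phenyl on the cyclohexyl core would address, and they leave open how other groups on this ring, such as methoxy, an amine or a carboxylic acid, would behave. Going by these compounds, it also remains open whether 3-cyanophenyl would have a similar effect with 4,4-difluorocyclohexyl or benzyl on the aromatic nitrogen.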